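Aryl groups in place of the ring amine hydrogen

The source may hold more compounds than are shown below. What is called first, only, known or untested is meant among the compounds shown, and "the series" means these compounds.

Measured so far:
compound 1 `O=C1Cc2cc(S(=O)(=O)N3CCNCC3)ccc2N1` — "not active" (no number reported)
compound 2 `Cc1ccc(N2CCN(S(=O)(=O)c3ccc4c(c3)CC(=O)N4)CC2)cc1` — "not active" (no number reported)
compound 3 `N#Cc1ccc(N2CCN(S(=O)(=O)c3ccc4c(c3)CC(=O)N4)CC2)cc1` — 3260 nM

In an assay on isolated protein for inhibition of lysosomal alpha-glucosidase (Homo sapiens), read by fluorescence, with stated times of 5 min and 45 min (a higher number here means a weaker inhibitor, a lower number a stronger inhibitor), compound 1 gives "not active" (no number reported), so no number fixes its place on the scale; compound 2 likewise gives "not active" (no number reported) in this assay. Only compound 3 yields a number in this assay, at 3260 nM. Compound 4 `O=C1Cc2cc(S(=O)(=O)N3CCN(c4ccc([N+](=O)[O-])cc4)CC3)ccc2N1` differs from compound 1 as follows: 4-nitrophenyl in place of hydrogen on an amine nitrogen in a ring. Within the data shown here, no measured step links these two, so the expectation rests on compound 3, which also carries an aryl group in place of hydrogen on the amine nitrogen and gives 3260 nM. In this assay the step from compound 1 to compound 4 is expected to move from no activity to a measurable number, toward stronger inhibition. The estimate for compound 4 in this assay is 3500 nM, between 800 nM and 15000 nM.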

Compound 4, half-maximal inhibitory concentration: 3260 nM
Compound 4: the middle estimate sits 1.1-fold (0.03 log units) above what was measured; the range from low to high includes it.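

In this assay the step shows no change at the digits printed from compound 3 to compound 4 (within the scatter), so nitro and nitrile on the aromatic carbon read alike in this series. Compound 2, with methyl on that carbon, gives "not active" (no number reported) in place of a number, so the aryl group on the ring amine nitrogen does not yield a number by itself. No evidence here accounts for this difference.

Still open, going by these compounds, is how an amine or a carboxylic acid on that aromatic carbon would read. A benzyl group in place of the aryl group on the ring amine nitrogen also remains untested in the compounds shown.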